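Adding a Nitro Group to Compound 2

A few compounds are considered here, and "the series" means these few. Any claim that something is new, unique, unknown or untested is made for them only; others in the source may bear on it.

Measured so far in a functional assay on MCF7 cells (Homo sapiens) for inhibition, read by MTT assay, with a stated time of 72 h; a higher number here means a weaker inhibitor, a lower number a stronger inhibitor:
- compound 1 `COc1ccc(C(=O)/C=C/c2cc(OC)c(OC)cc2OC)cc1` gives 33900 nM
- compound 2 `COc1cc(OC)c(OC)cc1/C=C/C(=O)c1ccccc1` gives > 150000 nM as a limit, not a number
- compound 3 `COc1cc(OC)c(OC)cc1/C=C/C(=O)c1ccc(C)cc1` gives 33000 nM

Compound 2 has only a limit, > 150000 nM, and no exact number.

Compound 4 `COc1cc(OC)c(OC)cc1/C=C/C(=O)c1cccc([N+](=O)[O-])c1` differs from compound 2 in one place, (nitro in place of hydrogen on an aromatic carbon), with nitro in place of hydrogen on an aromatic carbon. For the measured compounds named here, no measured compound carries nitro, so the evidence is indirect. Going by the values given here, three measured steps bear on this change. Putting methyl in place of that kind of hydrogen gave an at least 4.5-fold lower number from compound 2 to compound 3 (0.65 log units; beyond the scatter), while going the other way, hydrogen in place of methoxy, gave an at least 4.4-fold higher number from compound 1 to compound 2 (0.64 log units; beyond the scatter). Methyl in place of methoxy gave a 1.0-fold lower number from compound 1 to compound 3 (0.01 log units; within the scatter), so two different groups led to matching results. A similar move towards a lower number, meaning a stronger inhibitor, is therefore expected for nitro. The expected change is an at least 3.3-fold lower number from compound 2 to compound 4 (0.52 log units; beyond the scatter), though it starts from a limit. For compound 4 the estimate is 45000 nM, with an expected range from 15000 nM to 130000 nM in this assay.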

Compound 4, half-maximal inhibitory concentration: > 150000 nM
Compound 4 gave a limit, no number (the forecaster's own chance of this, stated with the estimate: 25%); middle value at least 3.3-fold (0.52 log units) from the limit.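

Compound 2 and compound 4 each give only a limit, not a number, so the step between them cannot be read: the limit of > 150000 nM in this assay, at which 2 of the 4 values shown sit.

The compounds shown leave open whether nitro in place of hydrogen on an aromatic carbon makes compound 4 a stronger or weaker inhibitor than compound 2, and by how much.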